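Cyclopropylcarbonyl Replaces Benzofuranylmethyl on the Ring Nitrogen

The source may hold more compounds than are shown below. What is called first, only, known or untested is meant among the compounds shown, and "the series" means these compounds.

Compound 1 `Fc1ccc(C(SCCNC2CCN(Cc3ccccc3)CC2)c2ccc(F)cc2)cc1`: 32.9 nM in an assay on membranes from striatum (strain Sprague-Dawley) for displacement of a labelled ligand from sodium-dependent dopamine transporter (Rattus norvegicus), read by scintillation counting, with a stated time of 120 min; on this read-out lower numbers stand for stronger inhibition and higher numbers for weaker inhibition
Compound 2 `Fc1ccc(C(SCCNC2CCN(Cc3cc4ccccc4o3)CC2)c2ccc(F)cc2)cc1`: 120 nM in this assay

Compound 2 holds the higher of the two numbers shown in this assay; the step of a 3.6-fold higher number from compound 1 to compound 2 (0.56 log units; beyond the scatter) sets it apart from compound 1. Compound 3 `O=C(C1CC1)N1CCC(NCCSC(c2ccc(F)cc2)c2ccc(F)cc2)CC1` differs from compound 2 by cyclopropylcarbonyl in place of (1-benzofuran-2-yl)methyl on an amine nitrogen in a ring. Going by the values given here, the single measured step, a 3.6-fold higher number from compound 1 to compound 2 (0.56 log units; beyond the scatter), exchanged one aromatic group for another on a saturated chain carbon bound to an amine nitrogen in a ring. The change to compound 3 is of another kind: the chain carbon and both of its aromatic rings leave, and an acyl group sits on the ring nitrogen instead. Among the compounds with values here, no measured pair covers such a change, and the measured step offers only a loose guide. The account expects a step of a 2.9-fold higher number from compound 2 to compound 3 (0.46 log units; beyond the scatter), toward a higher number, with wide uncertainty. Compound 3 is therefore estimated at 350 nM, within 60 nM to 2000 nM.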

Compound 3, inhibition constant: 178 nM
The estimate for compound 3 lay 2.0-fold (0.29 log units) above the measured number; measured number inside the range.
By their numbers in this assay, from the lowest: compound 1; then compounds 2 and 3 (each within the scatter of the next).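

On the amine nitrogen in a ring, the two fused aromatic rings of compound 2 prove dispensable in this assay: the much smaller cyclopropylcarbonyl group, with no aromatic ring, gives a 1.5-fold higher number from compound 2 to compound 3 (0.17 log units; within the scatter). Set against the benzyl group, the same acyl group gives a 5.4-fold higher number from compound 1 to compound 3 (0.73 log units; beyond the scatter), so compound 1 remains apart from both other compounds, while compounds 2 and 3 cannot be told apart despite their very different groups. No measurement offered here accounts for either step.

The compounds shown leave open whether the step away from benzyl follows from the carbonyl or from the three-membered ring, a question that cyclopropylmethyl or benzoyl on the same nitrogen would address. They also leave open how a simple acetyl group or a pyridin-2-ylmethyl group would read at this position.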